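Hydroxy to Cyano on the Pendant Phenyl Ring

The source may hold more compounds than are shown below. What is called first, only, known or untested is meant among the compounds shown, and "the series" means these compounds.

Compound 1 `CC(=O)N1N=C(c2cc(O)c(O)c([N+](=O)[O-])c2)CC1c1cccs1` and compound 2 `CC(=O)N1N=C(c2cc(O)c(O)c([N+](=O)[O-])c2)CC1c1cccc(O)c1` share one core and differ only in the group on a saturated ring carbon. In an assay on isolated protein for inhibition of Amine oxidase [flavin-containing] B (Homo sapiens), read by fluorescence (on this read-out higher numbers stand for weaker inhibition and lower numbers for stronger inhibition), compound 1 gives 69200 nM, and compound 2 gives 85200 nM; the step of a 1.2-fold higher number from compound 1 to compound 2 (0.09 log units; within the scatter) leaves the two values within the scatter of each other, so they cannot be told apart. Compound 3 `CC(=O)N1N=C(c2cc(O)c(O)c([N+](=O)[O-])c2)CC1c1cccc(C#N)c1` differs from compound 2 by cyano in place of hydroxy on an aromatic carbon. Within the data shown here, the only measured step, a 1.2-fold higher number from compound 1 to compound 2 (0.09 log units; within the scatter), touched the same pendant ring but swapped a whole ring rather than one group on it, and it stayed within the scatter. Among the measured compounds shown here, no measured compound carries a cyano group, so nothing anchors a direction. The step of a 1.0-fold lower number from compound 2 to compound 3 (0.00 log units; within the scatter) is therefore an expectation of no change beyond the scatter, not a measurement. In this assay compound 3 is estimated at 85000 nM, with a range from 30000 nM to 250000 nM.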

Compound 3, half-maximal inhibitory concentration: 55400 nM
Estimate against measurement, compound 3: 1.5-fold (0.19 log units) above; the range from low to high includes it.
By their numbers in this assay, from the lowest: compounds 3, 1 and 2 (each within the scatter of the next).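

Replacing hydroxy, which counts a hydrogen-bond donor, with cyano, which counts none, gives in this assay a 1.5-fold lower number from compound 2 to compound 3 (0.19 log units; within the scatter), so this single change on the phenyl ring does not separate the two compounds. Set against the five-membered ring of compound 1, the new group gives a 1.2-fold lower number from compound 1 to compound 3 (0.10 log units; within the scatter), which means that thiophen-2-yl, 3-hydroxyphenyl and 3-cyanophenyl on this saturated ring carbon cannot be told apart in these measurements. No independent measurement bears on why these three numbers lie so close together.

Going by these compounds, whether an amine, a carboxylic acid or a longer chain at the same place on the phenyl ring would move the number beyond the scatter remains open. Also open, on these data alone, is what the groups on the shared core contribute, since all three compounds carry that core unchanged.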